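Pyridyl for Pyrimidinyl at the Amide End

A few compounds are considered here, and "the series" means these few. Any claim that something is new, unique, unknown or untested is made for them only; others in the source may bear on it.

Compound 1 `O=C(CSc1nc2c(c(=O)n1-c1ccccc1)SCC2)Nc1ccc(-c2ccccn2)cc1`: 4 nM
Compound 2 `O=C(CSc1nc2c(c(=O)n1-c1ccccc1)SCC2)Nc1ccc(-c2cncnc2)cn1`: 5.5 nM
Compound 3 `O=C(CSc1nc2c(c(=O)n1-c1ccc(F)cc1)SCC2)Nc1nc2ccc(C(F)(F)F)cc2s1`: 100 nM

All three numbers come from an assay on L cells for inhibition of Protein-serine O-palmitoleoyltransferase porcupine (Mus musculus), read by reporter gene assay, with a stated time of 24 h; on this read-out lower numbers stand for an effect already at smaller amounts and higher numbers for an effect only at larger amounts of compound. On these numbers compound 2 stands second highest of the three; its nearest neighbour is compound 1, whose number is within the scatter of that of compound 2, so the two are not told apart. Compound 3 lies far higher, beyond the scatter, and differs from compound 2 in more than one place, so that gap is not assigned to any single change.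

The new compound, compound 4 `O=C(CSc1nc2c(c(=O)n1-c1ccccc1)SCC2)Nc1ccc(-c2cccnc2)cn1`, differs from compound 2 in one place: pyridin-3-yl in place of pyrimidin-5-yl on an aromatic carbon. For the measured compounds named here, no measured pair shows this same exchange, and compound 1 with its pyridin-2-yl on a different ring is not a direct guide. The change is small and keeps one ring nitrogen in the same sort of place, so no shift beyond the scatter is expected in this assay. Compound 4 is therefore estimated at 5 nM, within 2 nM to 15 nM, a step from compound 2 of a 1.1-fold lower number from compound 2 to compound 4 (0.04 log units; within the scatter) expected to fall inside the usual scatter.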

Compound 4, half-maximal effective concentration: 1 nM
The estimate for compound 4 lay 5.0-fold (0.70 log units) above the measured number; the whole stated range lies above it.
By their numbers in this assay, from the lowest: compound 4; then compounds 1 and 2 (each within the scatter of the next); then compound 3.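

In this assay, for the compounds shown here, pyridin-3-yl in place of pyrimidin-5-yl gives a 5.5-fold lower number from compound 2 to compound 4 (0.74 log units; beyond the scatter), the first change at a single place that can be read in this set. The two groups match in heavy atoms and differ in the entering group's fewer ring nitrogens and hydrogen-bond acceptors, so this position, para to a large group, is sensitive to the make-up of the ring it carries even when ring size stays the same. Nothing measured here explains the step.

As far as these compounds go, the step rests on one pair, so it remains open whether the same exchange would give a similar step on a different core or with another group at the amide end. From the compounds shown here alone, it also remains open how pyridin-4-yl, or a pyridin-3-yl ring carrying an amine or a carboxylic acid, would fare at this place.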